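Compound 3 to compound 4: swapping cyclohexyl for ethoxycarbonyl

The source may hold more compounds than are shown below. What is called first, only, known or untested is meant among the compounds shown, and "the series" means these compounds.

compound 1 `CCn1nc(-c2cccnc2)c2ccccc2c1=O` gives 1320 nM
compound 2 `O=c1c2ccccc2c(-c2cccnc2)nn1C1CCCC1` gives 2750 nM
compound 3 `O=c1c2ccccc2c(-c2cccnc2)nn1CC1CCCCC1` gives 209 nM

In a functional assay (trachea) with Cavia porcellus as the target (on this read-out lower numbers stand for stronger inhibition and higher numbers for weaker inhibition), compound 3 has the lowest of the three numbers (209 nM), and its steps to both other compounds lie beyond the scatter. Compound 4 `CCOC(=O)Cn1nc(-c2cccnc2)c2ccccc2c1=O` carries ethoxycarbonyl in place of cyclohexyl on a saturated chain carbon bound to an aromatic nitrogen.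

The closest measured change is the step of a 6.3-fold lower number from compound 1 to compound 3 (0.80 log units; beyond the scatter) with cyclohexyl in place of methyl at that same place. Read in reverse, it suggests that losing cyclohexyl raises the number by a modest step. The step of a 13-fold lower number from compound 2 to compound 3 (1.12 log units; beyond the scatter) shows that the group on the aromatic nitrogen can also move the number by a large amount. Among the measured compounds shown here, no measured compound carries an ester, so the data do not show how ethoxycarbonyl compares with methyl.

A rise is therefore expected, with an estimated 4.8-fold higher number from compound 3 to compound 4 (0.68 log units; beyond the scatter) as the working figure. The estimate for compound 4 is 1000 nM (expected range 300 nM to 3500 nM).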

Compound 4, half-maximal inhibitory concentration: 43700 nM
Compound 4: middle estimate off by 44-fold (1.64 log units), on the low side; the whole stated range lies below it.
By their numbers in this assay, from the lowest: compound 3; then compound 1; then compound 2; then compound 4.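

In this assay, the ethoxycarbonyl side chain on the saturated chain carbon bound to an aromatic nitrogen gives the highest number in the set, well past the cyclohexyl compound (a 210-fold higher number from compound 3 to compound 4 (2.32 log units; beyond the scatter)). The change is not simply a loss of cyclohexyl: ethoxycarbonyl also sits far above methyl (a 33-fold higher number from compound 1 to compound 4 (1.52 log units; beyond the scatter)), and (ethoxycarbonyl)methyl above cyclopentyl on the aromatic nitrogen (a 16-fold higher number from compound 2 to compound 4 (1.20 log units; beyond the scatter)), so this place responds strongly to the kind of group and not only to the presence of a ring. No measurement at hand accounts for the rise.

Whether the ester function itself or the open chain carries this effect stays unsettled, since a plain butyl chain is not among the compounds shown. A carboxylic acid or a primary amide at the same place would also help separate these readings.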